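A few compounds are considered here, and "the series" means these few. Any claim that something is new, unique, unknown or untested is made for them only; others in the source may bear on it.

Measured so far in an assay on CHO cells with Alpha-2B adrenergic receptor (Homo sapiens) as the target; on this read-out lower numbers stand for smaller maximal responses and higher numbers for larger maximal responses:
compound 1 `CC(C)Oc1ccccc1OC(C)C1=NCCN1` gives 0.5
compound 2 `C=CCc1cccc(CC=C)c1OC(C)C1=NCCN1` gives 0.65
compound 3 `C=C(C)c1ccccc1OC(C)C1=NCCN1` gives 0.4

Compound 3 holds the lowest of the three numbers in this assay; compound 1 sits within the scatter of it, while compound 2 lies beyond the scatter above it. Compound 4 `COc1ccccc1OC(C)C1=NCCN1` is still to be measured. Its change from compound 3: methoxy in place of 1-methylethenyl on an aromatic carbon. Among the measured compounds shown here, one measured step bears on this: a number 0.10 lower from compound 1 to compound 3 (within the scatter), which makes the reverse exchange at the same position with isopropoxy rather than methoxy and stays within the scatter. On that basis compound 4 is expected to differ from compound 3 by no more than the scatter, with an estimated step of a number 0.10 higher from compound 3 to compound 4 (within the scatter). Compound 4 is therefore estimated at 0.5, within 0.3 to 0.7.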

Compound 4, intrinsic activity: the largest response reached, as a fraction of the reference agonist's: 0.5
The estimate for compound 4 equals the measured number at the digits printed; the range from low to high includes it.
By their numbers in this assay, from the lowest: compounds 3, 1 and 4 (each within the scatter of the next); then compound 2.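

In this assay the exchange at this aromatic carbon gives a step (a number 0.10 higher from compound 3 to compound 4 (within the scatter)) that does not separate methoxy from 1-methylethenyl, even though methoxy brings a hydrogen-bond acceptor and removes the double bond. Methyl in place of isopropyl on the oxygen (no change at the digits printed from compound 1 to compound 4 (within the scatter)) adds that the size of this oxygen substituent does not separate these compounds either. No measured evidence accounts for these results.

Still open, on these data alone, is whether an amine, a carboxylic acid or a longer alkoxy chain at this position would move the maximal response beyond the scatter.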